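The compounds below may be only part of what the source reports. "The series", "measured", "known", "first", "only" and "open" are said of these compounds alone.

Measured in a functional assay on MDA-MB-231 cells (Homo sapiens) for antiproliferative activity, read by sulforhodamine B assay; on this read-out lower numbers stand for stronger inhibition of growth and higher numbers for weaker inhibition of growth:
- compound 1 `CC(C)CCCOc1cccc(O)c1C(=O)/C=C/c1ccc(O)cc1`: 3480 nM
- compound 2 `CCCCCCOc1cccc(O)c1C(=O)/C=C/c1ccc(O)cc1`: > 30000 nM

Compound 2 gives > 30000 nM, which is a limit of the assay and not a number. It therefore has no exact place on the scale, and the limit of > 30000 nM in this assay, at which 1 of the 2 values shown sits, is all that can be said of it.

Compound 3 `CC(C)(C)CCOc1cccc(O)c1C(=O)/C=C/c1ccc(O)cc1` has the same atoms as compound 2, joined differently: tert-butyl in place of butyl on a saturated chain carbon, two bonds along the chain from an oxygen on an aromatic ring. This turns hexyloxy into 3,3-dimethylbutoxy.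

Among the measured compounds shown here, one measured step bears on this change: an at least 8.6-fold higher number from compound 1 to compound 2 (0.93 log units; beyond the scatter). It lies beyond the scatter, and there propyl takes the place of isopropyl three bonds along the chain, whereas the present change falls two bonds along. Read in reverse, it points to a lower number in this assay for compound 3, but this single comparison fixes the size only loosely. The expected change is an at least 5.0-fold lower number from compound 2 to compound 3 (0.69 log units; beyond the scatter). For compound 3 the estimated value is 6000 nM, with an expected range of 2000 nM to 25000 nM.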

Compound 3, concentration for 50% growth inhibition: 2380 nM
Compound 3: middle estimate off by 2.5-fold (0.40 log units), on the high side, within the range that was stated.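

In this assay, the branched chain brings a large change at this place, two bonds along the chain from an oxygen on an aromatic ring: an at least 12-fold lower number from compound 2 to compound 3 (1.10 log units; beyond the scatter). The value of compound 2 is a limit of the assay and not a number, so that step gives only a lower bound on the change: the limit of > 30000 nM in this assay, at which 1 of the 3 values shown sits. Tert-butyl and isobutyl at this place do not separate, since the step is within the scatter: a 1.5-fold lower number from compound 1 to compound 3 (0.17 log units; within the scatter).

Going by these compounds, whether the branched chains of compound 1 and compound 3 would keep this level with a longer chain, or with a cyclohexyl group or an amine at the chain end, stays open. Also open, on these data alone, is how far branching nearer to the oxygen would carry, as the three compounds cover only these chains on one shared core.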